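A few compounds are considered here, and "the series" means these few. Any claim that something is new, unique, unknown or untested is made for them only; others in the source may bear on it.

In a functional assay on HCT-116 cells (Homo sapiens), read by MTT assay, with a stated time of 3 days (on this read-out lower numbers stand for stronger inhibition and higher numbers for weaker inhibition), compound 1 (`CNc1ncnc2[nH]cc(Sc3cccs3)c12`) gives 19000 nM. Compound 2 (`c1csc(Sc2c[nH]c3ncnc(-c4cccs4)c23)c1`) gives 13000 nM, and these two numbers lie within the scatter of each other, so compound 2 stands level with compound 1. Next is compound 3 (`Cc1ncnc2[nH]cc(Sc3cccs3)c12`), with methyl in place of thiophen-2-yl on an aromatic carbon, next to the ring nitrogen: methyl in place of thiophen-2-yl on an aromatic carbon. Among the compounds with values here, one measured step bears on this place: a 1.5-fold lower number from compound 1 to compound 2 (0.16 log units; within the scatter), thiophen-2-yl in place of methylamino, which stayed within the scatter. Methyl is not methylamino, so that step is only a loose guide. On that single step, no change beyond the scatter is expected in this assay, in either direction. For compound 3 the expected step is a 1.2-fold higher number from compound 2 to compound 3 (0.09 log units; within the scatter). Compound 3 is estimated at 16000 nM, with an expected range of 7000 nM to 35000 nM.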

Compound 3, half-maximal inhibitory concentration: 38100 nM
Beside the measured number, compound 3's estimate is 2.4-fold (0.38 log units) below it, and the stated range ends below it.
By their numbers in this assay, from the lowest: compounds 2, 1 and 3 (each within the scatter of the next, the first and the last beyond it).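

In this assay, this position on the aromatic carbon next to the ring nitrogen gives its first step beyond the scatter: replacing thiophen-2-yl with methyl gives a 2.9-fold higher number from compound 2 to compound 3 (0.47 log units; beyond the scatter). The earlier methylamino to thiophen-2-yl exchange did not separate its pair, and the methyl to methylamino comparison does not either, at a 2.0-fold higher number from compound 1 to compound 3 (0.30 log units; within the scatter), so the position's response so far rests on the modest gap between the thiophen-2-yl and methyl compounds alone. No measured evidence accounts for this step.

From the compounds shown here alone, whether a phenyl ring, a longer chain such as propyl or a dimethylamino group at this place would track thiophen-2-yl or methyl remains open. The three compounds also cannot tell whether the five-membered aromatic ring itself or only the larger heavy-atom count of thiophen-2-yl goes with the step.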